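Para-substituent swap on the anilide of compound 3

The source may report more compounds than this note shows. Statements on the series, on what has been measured and on what is new or still open speak of the compounds shown alone.

Three measured compounds share one core and differ only in the methyl position on the anilide ring. Compound 1 `COc1cc(-c2cc(C(=O)O)c3ccccc3n2)ccc1OCC(=O)Nc1ccccc1C` gives 0.8 in a physicochemical assay for lipophilicity, using the shake flask method, in phosphate buffer, measured as octanol-water partition, at pH 7.4; a higher number here means a more lipophilic compound, a lower number a more polar compound. Compound 2 `COc1cc(-c2cc(C(=O)O)c3ccccc3n2)ccc1OCC(=O)Nc1cccc(C)c1` gives 1.5 in this assay, and compound 3 `COc1cc(-c2cc(C(=O)O)c3ccccc3n2)ccc1OCC(=O)Nc1ccc(C)cc1` gives 1.2. The measured steps are a number 0.70 log units higher from compound 1 to compound 2 (beyond the scatter), a number 0.40 log units higher from compound 1 to compound 3 (beyond the scatter) and a number 0.30 log units lower from compound 2 to compound 3 (within the scatter); compound 3 thus stands clearly above compound 1, and within the scatter of compound 2.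

Compound 4 `COc1cc(-c2cc(C(=O)O)c3ccccc3n2)ccc1OCC(=O)Nc1ccc(F)cc1` differs from compound 3 by fluoro in place of methyl on an aromatic carbon. None of the three measured steps involves a fluoro group; all of them move a methyl around the anilide ring, and the largest of them is modest. Among the measured compounds shown here, no measured step therefore bears directly on this exchange, and the size of the step in this assay is uncertain in either direction, with only a small shift expected. The estimated step is a number 0.30 log units lower from compound 3 to compound 4 (within the scatter). For compound 4 the expected value in this assay is 0.9, within a range of 0.4 to 1.4.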

Compound 4, distribution coefficient: 1.1
Compound 4: the middle estimate sits 0.20 log units below what was measured; the range from low to high includes it.
By their numbers in this assay, from the lowest: compounds 1, 4, 3 and 2 (each within the scatter of the next, the first and the last beyond it).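

Among the compounds shown here, on the anilide, fluoro in place of methyl on an aromatic carbon, para to a large group, is the first exchange of one group for another at this position rather than a move of the methyl, and in this assay it reads as a number 0.10 log units lower from compound 3 to compound 4 (within the scatter). The other two steps fall differently: a number 0.40 log units lower from compound 2 to compound 4 (beyond the scatter), whereas a number 0.30 log units higher from compound 1 to compound 4 (within the scatter), so compound 4 stands clear of compound 2 only, while compound 3 stands clear of compound 1 only. No independent data accompany these compounds that could account for the result.

From the compounds shown here alone, whether other groups at this position, such as an amine, a nitrile or a trifluoromethyl group, would stay as close to compound 3 remains open. Also open, going by these compounds, is whether fluoro would read the same in the other two places the methyl occupies in compound 1 and compound 2.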